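Chloropropyl in place of cyclopropyl on a triazole

A few compounds are considered here, and "the series" means these few. Any claim that something is new, unique, unknown or untested is made for them only; others in the source may bear on it.

The measured compounds are compound 1 `O=C1O[C@H]([C@@H](O)Cn2cc(-c3cccc(O)c3)nn2)C(OCc2ccccc2)=C1OCc1ccccc1` with 42900 nM, compound 2 `O=C1O[C@H]([C@@H](O)Cn2cc(CNS(=O)(=O)c3ccc(F)cc3)nn2)C(OCc2ccccc2)=C1OCc1ccccc1` with 22900 nM, and compound 3 `O=C1O[C@H]([C@@H](O)Cn2cc(C3CC3)nn2)C(OCc2ccccc2)=C1OCc1ccccc1` with 30400 nM, all in a functional assay on HCT-116 cells (Homo sapiens) for antiproliferative activity, read by MTT assay, with a stated time of 72 h; a lower number here means a stronger inhibitor, a higher number a weaker inhibitor.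

Compound 3 sits between the other two on these numbers, and both of its gaps are within the scatter: a 1.3-fold higher number from compound 2 to compound 3 (0.12 log units; within the scatter) and a 1.4-fold lower number from compound 1 to compound 3 (0.15 log units; within the scatter). The third measured step, a 1.9-fold lower number from compound 1 to compound 2 (0.27 log units; within the scatter), is also within the scatter, so the three groups tried so far on the same aromatic carbon of the shared core have not moved this assay beyond its noise.

Compound 4 `O=C1O[C@H]([C@@H](O)Cn2cc(CCCCl)nn2)C(OCc2ccccc2)=C1OCc1ccccc1` is not yet measured. It differs from compound 3 by 3-chloropropyl in place of cyclopropyl on an aromatic carbon. Within the data shown here, the steps that bear on this change are the two that end at compound 3 and the one between compound 1 and compound 2, since all of them swap the group on that same aromatic carbon, and none of them exceeded the scatter. A flat outcome is therefore the expectation here: the number for compound 4 in this assay is expected to lie close to that of compound 3, with a 1.0-fold lower number from compound 3 to compound 4 (0.01 log units; within the scatter) meaning no step beyond the scatter. The estimate for compound 4 is 30000 nM, within a range from 12000 nM to 75000 nM.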

Compound 4, half-maximal inhibitory concentration: 36100 nM
Estimate against measurement, compound 4: 1.2-fold (0.08 log units) below; measured number inside the range.
By their numbers in this assay, from the lowest: compounds 2, 3, 4 and 1 (each within the scatter of the next).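

In this assay, replacing the three-membered ring of cyclopropyl with the open 3-chloropropyl chain, which brings in a chlorine, gives no step beyond the scatter (a 1.2-fold higher number from compound 3 to compound 4 (0.07 log units; within the scatter)), so at this aromatic carbon of the five-membered aromatic ring with 3 nitrogen neither the loss of the ring nor the gain of the chlorine can be told from noise. The new chain also stays within the scatter of the other two groups at this carbon (a 1.6-fold higher number from compound 2 to compound 4 (0.20 log units; within the scatter) and a 1.2-fold lower number from compound 1 to compound 4 (0.07 log units; within the scatter)), which extends the flat picture to four different groups: 3-hydroxyphenyl, the ((4-fluorophenyl)sulfonyl)amino-bearing methyl, cyclopropyl and now 3-chloropropyl. Nothing in the data at hand accounts for this flat result.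

The compounds shown leave open whether any group at this carbon can move this assay beyond the scatter, a question that an amine or a carboxylic acid at the end of the chain in place of the chlorine, or a longer chain, could address. A plain propyl group on the same carbon would also set the contribution of the chlorine apart from that of the chain.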